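Amino for Methyl: An Expected Step in the Rat

This account rests on a few compounds, and the source may have more. Where it says the series, first, only, none or still open, it means among the compounds named here.

Compound 1, `COc1cccc(-c2cc(Cl)cc(C(=O)Nc3nn[nH]n3)n2)c1`, gives 51% in a functional assay on the whole organism with Rattus norvegicus as the target, at a dose of 1 mg/kg by the oral route; a higher number here means a stronger effect of the compound at the dose given, a lower number a weaker effect.
Compound 2, `Cc1ccc(-c2cc(Cl)cc(C(=O)Nc3nn[nH]n3)n2)cc1`, gives 86% in this assay.

Among the compounds with values here, of the two numbers measured so far, compound 2 stands highest; its only neighbour, compound 1, lies lower by a margin beyond the scatter of repeated measurements. Compound 3, `Nc1ccc(-c2cc(Cl)cc(C(=O)Nc3nn[nH]n3)n2)cc1`, has not yet been measured in this assay. It differs from compound 2 by amino in place of methyl on an aromatic carbon. Within the data shown here, no pair of measured compounds shares this change, so nothing measured here shows how such a swap plays out; the expectation for compound 3 rests on compound 2 alone and is held loosely. A moderate fall is expected, a number 21 percentage points lower from compound 2 to compound 3 (beyond the scatter), though a step within the scatter cannot be ruled out. Compound 3 is expected to give 65% in this assay, with a range from 35% to 90%.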

Compound 3, a percentage reported as inhibition, in the whole organism at one dose (the size of the read-out at that dose, not a potency): 100%
Estimate against measurement, compound 3: 35 percentage points below; measured number outside the range, above it.
By their numbers in this assay, from the lowest: compound 1; then compound 2; then compound 3.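

Amino in place of methyl, taking 4-methylphenyl to 4-aminophenyl, proves to be tolerated at this position: in this assay the change gives a number 14 percentage points higher from compound 2 to compound 3 (beyond the scatter) and costs nothing at this dose. The place para to a large group on the six-membered aromatic ring can therefore hold a group with a hydrogen-bond donor and acceptor as well as one with neither, although a read-out at one dose shows the size of the effect and not a potency. Nothing measured here accounts for the gain, so its origin remains unexplained.

On these data alone, whether the gain is specific to amino or extends to hydroxyl, methylamino or dimethylamino at this place remains open. Also open, as far as these compounds go, is whether the same swap would hold on a core other than this one.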